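Cytotoxicity notes: methoxy for methyl on compound 2

The compounds below may be only part of what the source reports. "The series", "measured", "known", "first", "only" and "open" are said of these compounds alone.

Three anilides of one shared core have been run in an ADME assay on HEK293 cells (Homo sapiens) for cytotoxicity, read by MTT assay, with a stated time of 48 h; a lower number here means a stronger inhibitor, a higher number a weaker inhibitor. Compound 1 `Cc1cc(NC(=O)c2cccc(C(F)(F)F)c2)ccc1NS(C)(=O)=O` gives 194000 nM. Compound 2 `Cc1cc(NC(=O)c2cccc(C(F)(F)F)c2)ccc1NS(=O)(=O)C(F)(F)F` gives 131000 nM. Compound 3 `Cc1cc(NC(=O)c2cc(C(F)(F)F)cc(C(F)(F)F)c2)ccc1NS(=O)(=O)C(F)(F)F` gives 182000 nM. Of these three numbers that of compound 2 is the lowest, yet both gaps are within scatter: a 1.5-fold lower number from compound 1 to compound 2 (0.17 log units; within the scatter), and a 1.4-fold higher number from compound 2 to compound 3 (0.14 log units; within the scatter). Neither step therefore shows a movement in this assay that can be told from noise.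

Compound 4 `COc1cc(NC(=O)c2cccc(C(F)(F)F)c2)ccc1NS(=O)(=O)C(F)(F)F` is not yet measured. It differs from compound 2 by methoxy in place of methyl on an aromatic carbon. Among the measured compounds shown here, no measured step touches this place on the ring; the two known steps, on the sulfonyl sulfur and on the benzoyl ring, were both within scatter. Nothing in the series points to a change beyond scatter for this replacement, so the number for compound 4 in this assay is expected to stay close to that of compound 2, with a 1.1-fold higher number from compound 2 to compound 4 (0.03 log units; within the scatter) as the expected step. The estimate for compound 4 is 140000 nM, within a range of 60000 nM to 330000 nM.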

Compound 4, half-maximal inhibitory concentration: > 250000 nM
Compound 4: a limit, no number; the forecaster's own chance of this, stated with the estimate: 25%; middle value at least 1.7-fold (0.25 log units) away from the limit.
By their numbers in this assay, from the lowest: compounds 2, 3 and 1 (each within the scatter of the next). At a limit, above all of these: compound 4.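

In this assay compound 4 gives > 250000 nM, which is a limit and not a number. Methoxy in place of methyl on the aromatic carbon ortho to the ((trifluoromethyl)sulfonyl)amino group gives an at least 1.9-fold higher number from compound 2 to compound 4 (0.28 log units; that floor lies within the scatter), so this is the first step in the series with no upper bound, although its floor alone does not place it beyond the scatter. Among the compounds shown, this change at this position is the only one that leads to a limit, reached by compound 4 alone: the limit of > 250000 nM in this assay, at which 1 of the 4 values shown sits.

Going by these compounds, how far compound 4 truly lies from compound 2 stays unknown, so this step cannot be ranked against the two earlier steps. Also open, on these data alone, is whether an amine, a hydroxyl or a longer chain such as ethoxy at this position would give a number or a limit in this assay.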